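A few compounds are considered here, and "the series" means these few. Any claim that something is new, unique, unknown or untested is made for them only; others in the source may bear on it.

Measured so far in a functional assay on HCT-116 cells (Homo sapiens) for inhibition, read by MTT assay, with a stated time of 48 h; a lower number here means a stronger inhibitor, a higher number a weaker inhibitor:
- compound 1 `C/C=C/C(=O)N(Cc1cc(OC)c(OC)c(OC)c1)c1ccc(OC)c(O)c1`: 8450 nM
- compound 2 `COC(=O)c1cc(CNc2cc(OC)c(OC)c(OC)c2)ccc1OC`: 38100 nM
- compound 3 `COc1ccc(CN(C(=O)CBr)c2cc(OC)c(OC)c(OC)c2)cc1O`: 68 nM

Compound 2 stands at the highest of the three numbers. Its nearest neighbour is compound 1, whose number is lower by a gap beyond the scatter; compound 3 lies far lower still, again beyond the scatter. Within the data shown here, none of these pairs differs in a single place, so no single-change step is on hand to anchor what follows.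

The next compound in the series is compound 4 `COc1ccc(CNc2cc(OC)c(OC)c(OC)c2)cc1Cl`, which differs from compound 2 in one place: chloro in place of methoxycarbonyl on an aromatic carbon

Among the measured compounds shown here, no measured step resembles this change. The group that leaves carries two hydrogen-bond acceptors and the group that enters carries none; the ring it sits on is otherwise unchanged, and the rest of compound 2 is retained. With nothing comparable among the three measured compounds, the expectation for this assay is a step of modest size, tending towards a lower number than compound 2, with a wide range that also admits no change beyond the scatter. The expected step from compound 2 to compound 4 is a 1.5-fold lower number from compound 2 to compound 4 (0.18 log units; within the scatter). Compound 4 is accordingly estimated at 25000 nM, within 8000 nM to 80000 nM.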

Compound 4, half-maximal inhibitory concentration: 41700 nM
Beside the measured number, compound 4's estimate is 1.7-fold (0.22 log units) below it, and the stated range covers the measured number.
By their numbers in this assay, from the lowest: compound 3; then compound 1; then compounds 2 and 4 (each within the scatter of the next).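

In this assay, among these compounds, chloro in place of methoxycarbonyl gives a 1.1-fold higher number from compound 2 to compound 4 (0.04 log units; within the scatter), the only single-change step on hand. At this aromatic carbon, ortho to a methoxy group and meta to a large group, a group of 4 heavy atoms with 2 hydrogen-bond acceptors and a group of 1 heavy atom with none therefore read alike, so in this pair the acceptors and the extra heavy atoms of methoxycarbonyl make no difference beyond the scatter. No independent evidence bears on this result.

Going by these compounds, whether a carboxylic acid, a nitrile or a primary amine at this carbon would read the same remains open. Also open, on these data alone, is whether this exchange would give a similar step on a core with an acylated nitrogen, as in compound 3.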